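The source may hold more compounds than are shown below. What is called first, only, known or untested is meant among the compounds shown, and "the series" means these compounds.

Compound 1 `CCOc1cc(C(C)(C)C)ccc1C1=NC(c2ccc(Cl)cc2)C(c2ccc(Cl)cc2)N1C(=O)N1CCN(CCCCCCCC(=O)NO)CC1` and compound 2 `CCOc1cc(C(C)(C)C)ccc1C1=NC(c2ccc(Cl)cc2)C(c2ccc(Cl)cc2)N1C(=O)NCCCCCCC(=O)Nc1ccccc1N` share one core and differ in the chain hung from it. In an assay on isolated protein for inhibition of E3 ubiquitin-protein ligase Mdm2 (Homo sapiens), read by fluorescence polarization, with a stated time of 30 min (a lower number here means a stronger inhibitor, a higher number a weaker inhibitor), compound 1 gives 290 nM. Compound 2 gives 620 nM in this assay, so compound 1 has the lower of the two numbers, and the gap between them lies beyond the scatter. Compound 3 `CCOc1cc(C(C)(C)C)ccc1C1=NC(c2ccc(Cl)cc2)C(c2ccc(Cl)cc2)N1C(=O)N1CCN(CCCCCC(=O)NO)CC1` has not been measured; it differs from compound 1 by hydroxycarbamoyl in place of 2-(hydroxycarbamoyl)ethyl on a saturated chain carbon, five bonds along the chain from an amine nitrogen in a ring. Among the compounds with values here, no measured pair shows what such a shortening does, so only a small step is expected, a 1.4-fold higher number from compound 1 to compound 3 (0.14 log units; within the scatter), in no firm direction. For compound 3 in this assay the estimate is 400 nM, between 150 nM and 1100 nM.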

Compound 3, inhibition constant: 170 nM
Compound 3: the middle estimate sits 2.4-fold (0.37 log units) above what was measured; measured number inside the range.
By their numbers in this assay, from the lowest: compounds 3 and 1 (each within the scatter of the next); then compound 2.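

Putting hydroxycarbamoyl in place of 2-(hydroxycarbamoyl)ethyl on a saturated chain carbon, five bonds along the chain from an amine nitrogen in a ring, gives a 1.7-fold lower number from compound 1 to compound 3 (0.23 log units; within the scatter) in this assay. The two compounds therefore cannot be told apart here, and this chain can be shorter without a loss that this assay detects. No data shown here speak to why the shorter chain is tolerated. From the compounds shown here alone, whether a longer chain, or a carboxylic acid in place of hydroxycarbamoyl, would be tolerated as well stays open.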